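Dropping the para methyl from a weak hydrazone scaffold

A few compounds are considered here, and "the series" means these few. Any claim that something is new, unique, unknown or untested is made for them only; others in the source may bear on it.

Compound 3 `Cc1ccc(/C=N/NC(=N)NO)cc1` is one of three measured analogues that share a core with compound 1 `N=C(NO)N/N=C/c1ccccc1Cl` and compound 2 `N=C(NO)N/N=C/c1ccc(Cl)cc1`. In a functional assay on HL-60 cells (Homo sapiens) for antiproliferative activity (on this read-out lower numbers stand for stronger inhibition and higher numbers for weaker inhibition), compound 3 gives 67000 nM. Compound 1 gives 60000 nM in this assay, which sits within the scatter of the value of compound 3. For compound 2 the assay reports only a limit of > 100000 nM, which is a limit and not a number. The one step that joins two of these compounds, an at least 1.4-fold lower number from compound 2 to compound 3 (0.17 log units; that floor lies within the scatter), has a floor that lies within the scatter. Compound 4 `N=C(NO)N/N=C/c1ccccc1` has not yet been measured in this assay. It differs from compound 3 by hydrogen in place of methyl on an aromatic carbon. Within the data shown here, no measured step removes a methyl here, and the only step that touches this position has a floor within the scatter, so the step to compound 4 is expected to stay within the scatter, with some chance that this assay again reports only a limit, as the limit of > 100000 nM in this assay, at which 1 of the 3 values shown sits, shows for one value. Compound 4 is therefore estimated at 75000 nM, between 35000 nM and 160000 nM, a step of a 1.1-fold higher number from compound 3 to compound 4 (0.05 log units; within the scatter) that is expected to remain within the scatter.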

Compound 4, half-maximal inhibitory concentration: 62000 nM
Estimate against measurement, compound 4: 1.2-fold (0.08 log units) above; the range from low to high includes it.
By their numbers in this assay, from the lowest: compounds 1, 4 and 3 (each within the scatter of the next). At a limit, above all of these: compound 2.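

In this assay, the methyl on the aromatic carbon para to a group of 7 heavy atoms can give way to hydrogen with a 1.1-fold lower number from compound 3 to compound 4 (0.03 log units; within the scatter), and hydrogen in place of chloro gives a 1.0-fold higher number from compound 1 to compound 4 (0.01 log units; within the scatter), so neither substituent is separated from hydrogen on this read-out. A second replacement of chloro by hydrogen gives an at least 1.6-fold lower number from compound 2 to compound 4 (0.20 log units; that floor lies within the scatter), a floor that stays within the scatter. Compound 2 is reported only as a limit and not as a number: the limit of > 100000 nM in this assay, at which 1 of the 4 values shown sits.

The compounds shown carry only methyl, chloro or hydrogen, so it remains open whether an amine, a carboxylic acid or a longer chain at this position would move the number beyond the scatter. On these data alone, how far compound 2 truly lies from compound 4 also stays open.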